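Bromo to Iodo Without a Measured Anchor

The compounds below may be only part of what the source reports. "The series", "measured", "known", "first", "only" and "open" are said of these compounds alone.

In a functional assay on OVCAR-4 cells (Homo sapiens) for inhibition, read by sulforhodamine B assay, with a stated time of 48 h (on this read-out higher numbers stand for weaker inhibition of growth and lower numbers for stronger inhibition of growth), compound 1 (`Cc1ccc(NC(=O)/C=C/c2ccccc2)c(C(N)=O)c1`) gives 11400 nM. Compound 2 (`NC(=O)c1cc(Br)ccc1NC(=O)/C=C/c1ccccc1`) has no number to stand on, since compound 2 is reported as "not determined" (no result reported). Compound 3 (`NC(=O)c1cc(I)ccc1NC(=O)/C=C/c1ccccc1`) differs from it by one change, iodo in place of bromo on an aromatic carbon. Within the data shown here, no measured step exists for this exchange, so a shift in this assay beyond the usual scatter, in either direction, is not expected. Among the measured compounds shown here, the expectation rests on compound 1 at 11400 nM, the only measured neighbour. Compound 3 is estimated at 9000 nM, with an expected range of 3000 nM to 27000 nM.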

Compound 3, concentration for 50% growth inhibition: 1840 nM
Compound 3: the middle estimate sits 4.9-fold (0.69 log units) above what was measured; measured number outside the range, below it.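

In this assay the exchange of methyl for iodo gives a 6.2-fold lower number from compound 1 to compound 3 (0.79 log units; beyond the scatter) on the shared core, so this place, para to a large group, does not treat these two groups alike. Compound 2 has no number, so the step from bromo to iodo itself cannot be read, and nothing shows whether bromo would stand with methyl or with iodo. No measurement at hand gives a reason for the step from methyl to iodo. From the compounds shown here alone, whether chloro, an amine or a carboxylic acid at this place would stand nearer to methyl or to iodo remains open.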